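Replacing a Saturated Ring with a Naphthyl Ether

The source may hold more compounds than are shown below. What is called first, only, known or untested is meant among the compounds shown, and "the series" means these compounds.

Measured compounds:
Compound 1, `COc1cc(Cl)ccc1C[C@@H](C)C(=O)N1CCN(c2ccc(C)cc2[C@@H](N)CC(C)C)CC1`, in an assay on HEK293 cells for displacement of a labelled ligand from Melanocortin receptor 4 (Homo sapiens) (a lower number here means a stronger inhibitor, a higher number a weaker inhibitor), gives 8.1 nM.
Compound 2, `Cc1cc(Cl)ccc1CC(C)C(=O)N1CCN(c2ccc(C(F)(F)F)cc2[C@@H](N)CC(C)C)CC1`, in this assay gives 38 nM.
Compound 3, `CC(C)C[C@H](N)c1cc(C(F)(F)F)ccc1N1CCN(C(=O)CCC2CCCCC2)CC1`, in this assay gives 5700 nM.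

Compound 3 stands highest of the three numbers, so it is the weakest binder here; its steps to compound 2 and to compound 1 are both beyond the scatter. The new compound, compound 4, `CC(C)C[C@H](N)c1cc(C(F)(F)F)ccc1N1CCN(C(=O)COc2ccc3ccccc3c2)CC1`, differs from compound 3 in one place: (naphthalen-2-yl)oxy in place of cyclohexylmethyl on a saturated chain carbon bound to a carbonyl carbon.

For the measured compounds named here, one measured step bears on this change. Going a 150-fold higher number from compound 2 to compound 3 (2.18 log units; beyond the scatter), the benzyl-bearing chain on the carbonyl carbon was exchanged for a 2-cyclohexylethyl chain, and binding fell sharply. Compound 4 reverses the direction of that kind of exchange, bringing in 2 six-membered aromatic rings of carbon only where a six-membered non-aromatic ring stood. A step of meaningful size toward stronger binding is therefore expected, though the entering group is larger and carries an oxygen, so the full recovery to the level of compound 2 is not assumed; the expected step is a 9.5-fold lower number from compound 3 to compound 4 (0.98 log units; beyond the scatter). Compound 4 is estimated at 600 nM, within 120 nM to 3000 nM.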

Compound 4, inhibition constant: 2000 nM
Compound 4: middle estimate off by 3.3-fold (0.52 log units), on the low side, and the stated range covers the measured number.
By their numbers in this assay, from the lowest: compound 1; then compound 2; then compound 4; then compound 3.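

In this assay, (naphthalen-2-yl)oxy in place of cyclohexylmethyl gives a 2.9-fold lower number from compound 3 to compound 4 (0.45 log units; beyond the scatter) and so shows that binding responds to a change at this saturated chain carbon, even when the chain length stays the same. Aromatic rings at this place do not by themselves restore binding, though: there is still a 53-fold higher number from compound 2 to compound 4 (1.72 log units; beyond the scatter) when ((naphthalen-2-yl)oxy)methyl stands in place of 1-(4-chloro-2-methylbenzyl)ethyl on a carbonyl carbon. No measurement shown here explains the size of either step.

The oxygen and the two aromatic rings enter together in compound 4, so the compounds shown leave open which of them accounts for the gain. A phenoxy group, or a naphthalen-2-ylmethyl group with carbon in place of the oxygen, would pull those two features apart.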